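Bromo on the indole in a series pinned at the ceiling

The source may hold more compounds than are shown below. What is called first, only, known or untested is meant among the compounds shown, and "the series" means these compounds.

Compound 3 `CO[C@@H]1[C@H](N(C)c2ncc(-c3c[nH]c4ccccc34)s2)C[C@H]2O[C@]1(C)n1c3ccccc3c3c4c(c5c6cc(Br)ccc6n2c5c31)C(=O)NC4` belongs to a set of three close analogues on one shared core, differing only in the halogen on that core and in the substituent on the indole. In a functional assay on K562 cells (Homo sapiens) for antiproliferative activity, read by CellTiter-Glo, with a stated time of 72 h (on this read-out higher numbers stand for weaker inhibition and lower numbers for stronger inhibition), compound 3 gives only a limit, > 10000 nM. Compound 1 `CO[C@@H]1[C@H](N(C)c2ncc(-c3c[nH]c4ccccc34)s2)C[C@H]2O[C@]1(C)n1c3ccccc3c3c4c(c5c6cc(Cl)ccc6n2c5c31)C(=O)NC4` in this assay likewise gives a limit, > 10000 nM. Compound 2 `CO[C@@H]1[C@H](N(C)c2ncc(-c3c[nH]c4ccc(F)cc34)s2)C[C@H]2O[C@]1(C)n1c3ccccc3c3c4c(c5c6cc(Cl)ccc6n2c5c31)C(=O)NC4` gives a limit as well, > 10000 nM. The two measured steps, a step that the two limits leave unreadable from compound 1 to compound 2 and a step that the two limits leave unreadable from compound 1 to compound 3, therefore remain unreadable in size and direction, since (the limit of > 10000 nM in this assay, at which 3 of the 3 values shown sit). Compound 3 thus stands at the ceiling of this assay with no number of its own, level with its two neighbours as far as the limits allow.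

Compound 4 `CO[C@@H]1[C@H](N(C)c2ncc(-c3c[nH]c4ccc(Br)cc34)s2)C[C@H]2O[C@]1(C)n1c3ccccc3c3c4c(c5c6cc(Br)ccc6n2c5c31)C(=O)NC4` differs from compound 3 by bromo in place of hydrogen on an aromatic carbon. For the measured compounds named here, the nearest precedent, a halogen entering the indole, is a step that the two limits leave unreadable from compound 1 to compound 2, and it is unreadable; a step that the two limits leave unreadable from compound 1 to compound 3 is unreadable too. Nothing measured here points to a gain strong enough to bring the series below the limit. Compound 4 is therefore expected to rest at the ceiling as well, with an estimate of 15000 nM spanning 4000 nM to 50000 nM. The expected step that the limit leaves unreadable from compound 3 to compound 4 is none beyond the scatter, most likely reported as a limit again.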

Compound 4, half-maximal inhibitory concentration: > 10000 nM
Compound 4 gave a limit, no number; the forecaster's own chance of this, stated with the estimate: 80%; the middle value lies beyond the limit too.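

In this assay compound 4 gives > 10000 nM as a limit and not a number. For the compounds shown here, no step from compound 3 to compound 4 can be read, since the series sits at one ceiling: the limit of > 10000 nM in this assay, at which 4 of the 4 values shown sit. The compounds shown leave open whether any halogen change on this core gives a measurable antiproliferative value, and how large such a change would be.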